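Two-substituent chromone series: imine versus hydrazone at the core

This account rests on a few compounds, and the source may have more. Where it says the series, first, only, none or still open, it means among the compounds named here.

Measured so far:
compound 1, `O=c1cc(/C=N\c2ccc(O)cc2)c2c(OCc3ccccc3)cc(OCc3ccccc3)cc2o1`, 249000 nM
compound 2, `O=c1cc(-c2nc3ccccc3[nH]2)c2ccc(OCc3ccccc3)cc2o1`, 146000 nM

Both numbers come from a functional assay, read by spectrophotometry, with a stated time of 5 min; a higher number here means a weaker inhibitor, a lower number a stronger inhibitor. Of the two numbers shown, compound 1 and compound 2 lie within the scatter of each other, so no ranking between them can be read; both are weak inhibitors in this assay. For the measured compounds named here, no step between measured compounds that differ in a single place is available, so nothing in the measured set tells how a change at the double-bonded nitrogen moves the number.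

Compound 3, `O=c1cc(/C=N\Nc2ccc([N+](=O)[O-])cc2)c2c(OCc3ccccc3)cc(OCc3ccccc3)cc2o1`, is the next compound to be measured in this assay. It differs from compound 1 as follows: (4-nitrophenyl)amino in place of 4-hydroxyphenyl on a double-bonded nitrogen. Without any measured step to lean on, the expectation is a step from compound 1 to compound 3 of about a 1.1-fold lower number from compound 1 to compound 3 (0.05 log units; within the scatter), that is, none beyond the scatter in either direction. Compound 3 is therefore estimated at 220000 nM in this assay, with a range from 60000 nM to 800000 nM.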

Compound 3, half-maximal inhibitory concentration: 419000 nM
Beside the measured number, compound 3's estimate is 1.9-fold (0.28 log units) below it, and the stated range covers the measured number.
By their numbers in this assay, from the lowest: compounds 2, 1 and 3 (each within the scatter of the next, the first and the last beyond it).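

In this assay, for the compounds shown here, the step at this position, a 1.7-fold higher number from compound 1 to compound 3 (0.23 log units; within the scatter), is the first comparison between compounds that differ in one place, and it lies within the scatter. On a double-bonded nitrogen, (4-nitrophenyl)amino in place of 4-hydroxyphenyl therefore gives no readable difference, even though the entering group has more heavy atoms and hydrogen-bond acceptors and the aromatic ring and the donor count stay the same; the two benzyloxy-bearing compounds remain weak inhibitors with this change. No measurement here bears on why the number fails to separate the two groups.

This single step changes the amino link and the ring substituent together, so a phenylamino or (4-hydroxyphenyl)amino group would be needed to tell the two changes apart. On these data alone, whether any group at this position can move the number beyond the scatter also remains open, for example a short alkyl chain or a phenyl ring bearing a carboxylic acid or an amine.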